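From isobutyl to hexyloxy on the aromatic ring

The source may report more compounds than this note shows. Statements on the series, on what has been measured and on what is new or still open speak of the compounds shown alone.

In a functional assay on MCF7 cells (Homo sapiens) for antiproliferative activity, read by sulforhodamine B assay, with a stated time of 48 h (a lower number here means a stronger inhibitor, a higher number a weaker inhibitor), the measured compounds read as follows
compound 1 `CCc1ccc(NS(=O)(=O)c2ccc(N3CCNC3=O)cc2)cc1` gives 810 nM
compound 2 `COc1ccc(NS(=O)(=O)c2ccc(N3CCNC3=O)cc2)cc1` gives the limit > 1000 nM
compound 3 `CC(C)Cc1ccc(NS(=O)(=O)c2ccc(N3CCNC3=O)cc2)cc1` gives the limit > 1000 nM

Compound 3 stands only at a limit and has no number, a position it shares with compound 2 (the limit of > 1000 nM in this assay, at which 2 of the 3 values shown sit). Compound 4 `CCCCCCOc1ccc(NS(=O)(=O)c2ccc(N3CCNC3=O)cc2)cc1` has hexyloxy in place of isobutyl on an aromatic carbon, para to a large group (hexyloxy in place of isobutyl on an aromatic carbon). Among the measured compounds shown here, three measured steps bear on this change. Methoxy in place of ethyl on an aromatic carbon gave an at least 1.2-fold higher number from compound 1 to compound 2 (0.09 log units; that floor lies within the scatter) in the readout. Isopropyl in place of methyl on a saturated chain carbon bound to an aromatic carbon gave an at least 1.2-fold higher number from compound 1 to compound 3 (0.09 log units; that floor lies within the scatter) in the readout. Isobutyl in place of methoxy on an aromatic carbon gave a step that the two limits leave unreadable from compound 2 to compound 3 as its only reading. None of these readings reaches beyond the scatter, so no step beyond the scatter is expected in this assay and no firm direction can be given. The estimated step is a step that the limit leaves unreadable from compound 3 to compound 4 at most modest in size. For compound 4 the expected value is 1500 nM with an estimated range from 500 nM to 5000 nM and a reading at the limit is likely.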

Compound 4, half-maximal inhibitory concentration: > 1000 nM
Compound 4 ended at the assay's limit (the forecaster's own chance of this, stated with the estimate: 65%); the middle value lies beyond the limit too.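

In this assay, compound 4 gives > 1000 nM, which is a limit of the assay and not a number. Among the compounds shown here, the steps to compound 4 from compound 2 and from compound 3 cannot be read, and the one readable step is an at least 1.2-fold higher number from compound 1 to compound 4 (0.09 log units; that floor lies within the scatter). Hexyloxy, with its 7 heavy atoms and one hydrogen-bond acceptor in place of the 4 heavy atoms of isobutyl, thus adds a third compound at this limit, so that a longer ether on this aromatic carbon gave no measured number either: the limit of > 1000 nM in this assay, at which 3 of the 4 values shown sit.

For the compounds shown here, compound 1 remains the only compound with a number, and how far compound 2, compound 3 and compound 4 lie from one another stays open. From the compounds shown here alone, how an amine, a carboxylic acid or a short ether such as ethoxy would read at this place also stays open.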